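The compounds below may be only part of what the source reports. "The series", "measured", "known", "first", "only" and "open" are said of these compounds alone.

Three compounds sharing the same core, each bearing two sulfonamide groups, have been tested in an assay for inhibition of liver carboxylesterase 1 (Homo sapiens), read by spectrophotometry; a lower number here means a stronger inhibitor, a higher number a weaker inhibitor. Compound 1, `Cc1ccc(S(=O)(=O)Nc2ccc(NS(=O)(=O)c3cc(F)ccc3F)cc2)cc1`, gives > 100000 nM, which is a limit of the assay rather than a number. Compound 2, `O=S(=O)(Nc1cc(Br)c(NS(=O)(=O)c2ccccc2)cc1Br)c1ccccc1`, gives > 100000 nM, again only a limit. Compound 3, `O=S(=O)(Nc1ccc(NS(=O)(=O)c2ccc(Br)cc2)cc1)c1ccc(Br)cc1`, gives > 100000 nM, also a limit. Compound 1 therefore stands nowhere in particular among these results: all three values sit at the limit of > 100000 nM in this assay, at which 3 of the 3 values shown sit, and no step between any two of them can be sized, since none of them produced a measurable number.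

Compound 4, `Cc1ccc(S(=O)(=O)Nc2ccc(NS(=O)(=O)c3ccc(Cl)cc3)cc2)cc1`, has not yet been measured. It differs from compound 1 in a single place: 4-chlorophenyl in place of 2,5-difluorophenyl on a sulfonyl sulfur. Going by the values given here, with every measured compound sitting at the same limit, there is no measured step that would indicate how such a change shifts potency, and compounds 2 and 3 give no further guidance either.

The expected step is a number no higher from compound 1 to compound 4 (the limit leaves the size open), that is, no movement beyond the scatter of this assay. Compound 4 is accordingly estimated at 100000 nM, with a plausible range from 30000 nM to 300000 nM, and the most likely outcome is that the assay once more reports only a limit.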

Compound 4, inhibition constant: > 100000 nM
Compound 4 was reported as a limit; the forecaster's own chance of this, stated with the estimate: 85%; the middle value lies on the limit itself.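

In this assay compound 4 gives > 100000 nM, which is a limit and not a number. The step between compound 1 and compound 4 therefore cannot be read, since all the results rest on one limit: the limit of > 100000 nM in this assay, at which 4 of the 4 values shown sit. The compounds shown leave open what change, if any, would give a measurable inhibition constant in this assay.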